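Series notes: nitro in place of hydrogen on an aromatic carbon

A few compounds are considered here, and "the series" means these few. Any claim that something is new, unique, unknown or untested is made for them only; others in the source may bear on it.

Of the compounds shown here, two have been measured so far. In an in vitro assay on BTI-TN-5B1-4 cells for inhibition of Amine oxidase [flavin-containing] A (Homo sapiens), read by fluorescence, with a stated time of 15 min (on this read-out lower numbers stand for stronger inhibition and higher numbers for weaker inhibition), compound 1 `CC(=O)c1cc2cc(Cl)cc(Br)c2oc1=O` gives 55200 nM. In the same this assay compound 2 `O=C(NNc1ccccc1)c1cc2ccccc2oc1=O` gives 41400 nM, and the two numbers lie within the scatter of each other, so nothing separates them. Compound 3 `O=C(NNc1ccccc1[N+](=O)[O-])c1cc2ccccc2oc1=O` differs from compound 2 by nitro in place of hydrogen on an aromatic carbon. Among the measured compounds shown here, no measured pair shows the effect of such a change, so in this assay no step beyond the scatter is expected in either direction, and the range is kept wide. Compound 3 is therefore estimated at 35000 nM, between 9000 nM and 120000 nM, which means an expected step of a 1.2-fold lower number from compound 2 to compound 3 (0.07 log units; within the scatter).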

Compound 3, half-maximal inhibitory concentration: 39600 nM
Compound 3: the middle estimate sits 1.1-fold (0.05 log units) below what was measured, within the range that was stated.
By their numbers in this assay, from the lowest: compounds 3, 2 and 1 (each within the scatter of the next).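

In this assay, among the compounds shown here, nitro in place of hydrogen on an aromatic carbon, ortho to a large group, gives a 1.0-fold lower number from compound 2 to compound 3 (0.02 log units; within the scatter) and so is the first direct reading at this position. On this single pair, the position accepts a group of 3 heavy atoms with no step beyond the scatter. No evidence at hand bears on this result.

As far as these compounds go, whether an amine or a carboxylic acid at this position would give a step beyond the scatter remains open. The compounds shown also leave open whether nitro would behave alike on another part of the molecule.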